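The source may hold more compounds than are shown below. What is called first, only, known or untested is meant among the compounds shown, and "the series" means these compounds.

- compound 1 `CCCCCCCCCCCCC/C=C/[C@@H](O)[C@H](CO)n1cc(CCC)nn1`: 13000 nM
- compound 2 `CCCCCCCCCCCCCC[C@@H](O)[C@@H](O)[C@H](CO)n1cc(CCCCCC)nn1`: 12600 nM

In a functional assay on K562 cells (Homo sapiens) for cytotoxicity, read by MTT assay (a lower number here means that less compound is needed, a higher number that more compound is needed for the effect), compound 1 stands level with compound 2, the two values lying within the scatter of each other. Compound 3 `CCCCCCCCCCCCC/C=C/[C@@H](O)[C@H](CO)n1cc(CCCC)nn1` is compound 1 with one change: methyl in place of hydrogen on a saturated chain carbon, three bonds along the chain from an aromatic carbon, so that propyl becomes butyl. Within the data shown here, no measured step shows what this change does, so no shift beyond the scatter is expected. The expected change is a 1.1-fold lower number from compound 1 to compound 3 (0.03 log units; within the scatter). For compound 3 the estimated value is 12000 nM, with an expected range of 6500 nM to 22000 nM.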

Compound 3, half-maximal effective concentration: 12300 nM
Estimate against measurement, compound 3: 1.0-fold (0.01 log units) below, within the range that was stated.
By their numbers in this assay, from the lowest: compounds 3, 2 and 1 (each within the scatter of the next).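

Methyl in place of hydrogen on a saturated chain carbon, three bonds along the chain from an aromatic carbon, turns propyl into butyl and gives a 1.1-fold lower number from compound 1 to compound 3 (0.02 log units; within the scatter) in this assay. Among these compounds, this is the first direct reading of this position, and here the change leaves the value within the scatter. No outside evidence bears on this result.

The compounds shown leave open whether a longer chain, an amine or a carboxylic acid in place of butyl would shift the value in this assay beyond the scatter.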